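The source may hold more compounds than are shown below. What is called first, only, known or untested is meant among the compounds shown, and "the series" means these compounds.

Compound 1 `C=CCOc1cc(/C=C/C(=O)c2ccc(OC)c3c2OC(C)(C)C=C3)ccc1OC` in an ADME assay on L02 cells (Homo sapiens) for cytotoxicity, read by MTT assay (on this read-out lower numbers stand for stronger inhibition and higher numbers for weaker inhibition), gives > 20000 nM, a limit of the assay.
Compound 2 `COc1ccc(/C=C/C(=O)c2ccc(OC)c3c2OC(C)(C)C=C3)cc1OCCO` in this assay gives > 10000 nM, a limit of the assay.
Compound 3 `COc1ccc(/C=C/C(=O)c2ccc(OC)c3c2OC(C)(C)C=C3)cc1OC(=O)C(C)C` in this assay gives > 10000 nM, again a limit.

Compound 2 thus stands only at a limit, as do the two further values shown. The steps a step that the two limits leave unreadable from compound 1 to compound 2, a step that the two limits leave unreadable from compound 1 to compound 3 and a step that the two limits leave unreadable from compound 2 to compound 3 cannot be sized, since the limit of > 10000 nM in this assay, at which 2 of the 3 values shown sit, and the limit of > 20000 nM in this assay, at which 1 of the 3 values shown sits, cap every value recorded. Compound 4 `COc1ccc(/C=C/C(=O)c2ccc(OC)c3c2OC(C)(C)C=C3)cc1OC(=O)c1ccc(Br)cc1` differs from compound 2 by (4-bromophenyl)carbonyl in place of 2-hydroxyethyl on an oxygen on an aromatic ring. The measured steps on the shared core bear on this change only by showing that no variation at this oxygen yet produced a readable value, so no step beyond the scatter is expected; the estimated step is a step that the limit leaves unreadable from compound 2 to compound 4. Compound 4 is therefore expected to give 15000 nM, within 7000 nM to 40000 nM, most likely once more reported only as a limit.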

Compound 4, half-maximal inhibitory concentration: 8400 nM
Beside the measured number, compound 4's estimate is 1.8-fold (0.25 log units) above it; low and high end bracket the measured number.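

Among the compounds shown here, compound 4 gives 8400 nM in this assay, the only value shown for a group on this oxygen that is a number and not a limit. The change reads as an at least 1.1-fold lower number from compound 2 to compound 4 (0.07 log units; that floor lies within the scatter) and as an at least 1.1-fold lower number from compound 3 to compound 4 (0.07 log units; that floor lies within the scatter), while only an at least 2.3-fold lower number from compound 1 to compound 4 (0.37 log units; beyond the scatter) goes beyond the scatter. The first two steps remain floors set by a limit: the limit of > 10000 nM in this assay, at which 2 of the 4 values shown sit.

As far as these compounds go, whether the bromine matters remains open, and a phenylcarbonyl group without it would address this. So does the effect of an amine-bearing chain on this oxygen.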